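The source may report more compounds than this note shows. Statements on the series, on what has been measured and on what is new or still open speak of the compounds shown alone.

Compound 1, `OCCn1cc2c(Nc3ccc(OC(F)(F)F)cc3)ncnc2n1`, reaches only the assay limit > 10000 nM in an ADME assay on BaF3 cells (Mus musculus) for cytotoxicity; a lower number here means that less compound is needed, a higher number that more compound is needed for the effect.
Compound 2, `FC(F)(F)Oc1ccc(Nc2ncnc3nn(Cc4cccnc4)cc23)cc1`, also reaches only the assay limit > 10000 nM in this assay.

Compound 2 therefore stands at a limit, not at a measured number. Among the measured compounds shown here, the one measured step, a step that the two limits leave unreadable from compound 1 to compound 2, cannot be read because both values sit at the limit of > 10000 nM in this assay, at which 2 of the 2 values shown sit. Compound 3, `CCn1cc2c(Nc3ccc(OC(F)(F)F)cc3)ncnc2n1`, carries methyl in place of pyridin-3-yl on a saturated chain carbon bound to an aromatic nitrogen. For the measured compounds named here, no measured step bears on this change in a readable way. With both neighbours at the limit, compound 3 is expected to give about 20000 nM, most likely reported again as a limit, in a range from 8000 nM to 60000 nM. That expectation corresponds to a step that the limit leaves unreadable from compound 2 to compound 3.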

Compound 3, half-maximal effective concentration: > 10000 nM
Compound 3: a limit, no number; the forecaster's own chance of this, stated with the estimate: 80%; the middle value is on the limit's open side.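

Compound 3 also gives only a limit, not a number, so its steps from compound 1 and compound 2 cannot be read: the limit of > 10000 nM in this assay, at which 3 of the 3 values shown sit.

As far as these compounds go, whether pyridin-3-yl, hydroxymethyl and methyl differ at all in this assay stays open.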